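The compounds below may be only part of what the source reports. "The series", "measured", "known", "first", "only" and "open" are said of these compounds alone.

Compound 1 `COc1ccc([C@H](CC(=O)O)N2CCN(CCCc3ccc4c(n3)NCCC4)C2=O)cn1`: 88%
Compound 2 `COc1ccc([C@H](CC(=O)O)N2CCN(CCCc3nc4c(cc3C)CCCN4)C2=O)cn1`: 78%

Both values come from an ADME assay on a cell-free system (plasma, Homo sapiens) for binding affinity. Going by the values given here, the only measured step, a 1.8-fold higher unbound fraction from compound 1 to compound 2 (0.26 log units; within the scatter), is a methyl in place of hydrogen on an aromatic carbon, so compound 2 stands level with compound 1 within the scatter.

Compound 3 `COc1ccc([C@H](CC(=O)O)N2CCN(CCCc3ccc4c(n3)N[C@H](C)CC4)C2=O)cn1` has the same atoms as compound 2, joined differently: a group of 11 heavy atoms (9 carbon, 2 nitrogen; one six-membered non-aromatic ring with 1 hetero atom, one six-membered aromatic ring with 1 hetero atom) in place of a group of 11 heavy atoms (9 carbon, 2 nitrogen; one six-membered non-aromatic ring with 1 hetero atom, one six-membered aromatic ring with 1 hetero atom), on a saturated chain carbon, three bonds along the chain from an amide-type nitrogen in a ring. Among the compounds with values here, no measured pair shows this change directly, so the evidence is thin. Within the data shown here, the one guide is the step from the previous comparison, a 1.8-fold higher unbound fraction from compound 1 to compound 2 (0.26 log units; within the scatter), which did not exceed the scatter. A step beyond the scatter is therefore not expected here, and the direction is uncertain. The expected step is a 1.4-fold lower unbound fraction from compound 2 to compound 3 (0.14 log units; within the scatter). The estimate for compound 3 is 84%, with an expected range from 68% to 93%.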

Compound 3, plasma protein binding: 92%
The estimate for compound 3 lay 2.0-fold (0.30 log units) (unbound fraction) above the measured number; the measured number falls inside the stated range.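

In this assay, going by these compounds alone, the same atoms joined differently can matter: with the methyl on a saturated ring carbon rather than on an aromatic carbon, the result is a 2.8-fold lower unbound fraction from compound 2 to compound 3 (0.44 log units; beyond the scatter) and this is the first step to pass the scatter, though only modestly. Against the compound with no methyl, the methyl on the saturated ring carbon gives a 1.5-fold lower unbound fraction from compound 1 to compound 3 (0.18 log units; within the scatter) so compound 3 stands level with compound 1, and neither methyl on its own moves the value beyond the scatter. No supporting measurement bears on why the two placements differ.

The compounds shown leave open whether the opposite arrangement at the defined stereocentre of compound 3 gives a similar value. They also leave open how an ethyl or a fluorine on that saturated ring carbon would compare with the methyl.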